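This account rests on a few compounds, and the source may have more. Where it says the series, first, only, none or still open, it means among the compounds named here.

Compound 1 `CCCc1c(COc2ccc(C(=O)CCC(=O)O)cc2)ccc(C(C)=O)c1O` and compound 2 `CCCc1c(COc2ccc(C(=O)CCc3nnn[nH]3)cc2)ccc(C(C)=O)c1O` share one core and differ only at the far end of the chain. In an in vivo functional assay on the whole organism (Rattus norvegicus) with cysteinyl leukotriene receptor (Homo sapiens) as the target (a lower number here means that less compound is needed, a higher number that more compound is needed for the effect), compound 1 gives 18.2 mg/kg, and compound 2 gives 10.1 mg/kg; a 1.8-fold lower number from compound 1 to compound 2 (0.26 log units; within the scatter). Of the two numbers, compound 2 has the smaller, yet compound 1 sits within the scatter of it, so the pair cannot be separated. Compound 3 `CCCc1c(COc2ccc(C(=O)C(C)Cc3nnn[nH]3)cc2)ccc(C(C)=O)c1O` carries methyl in place of hydrogen on a saturated chain carbon bound to a carbonyl carbon and a saturated chain carbon. Among the measured compounds shown here, no measured step involves a change of this kind, and the single step known is within the scatter, so compound 3 is expected to show a 1.0-fold lower number from compound 2 to compound 3 (0.00 log units; within the scatter), nothing beyond the scatter. For compound 3 the estimate is 10 mg/kg, with a range from 4 mg/kg to 25 mg/kg.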

Compound 3, dose for half-maximal effect: 9.2 mg/kg
For compound 3 the middle estimate is 1.1-fold (0.04 log units) above the measured one; measured number inside the range.
By their numbers in this assay, from the lowest: compounds 3, 2 and 1 (each within the scatter of the next).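

In this assay, methyl in place of hydrogen on a saturated chain carbon bound to a carbonyl carbon and a saturated chain carbon gives a 1.1-fold lower number from compound 2 to compound 3 (0.04 log units; within the scatter) and thus no readable difference, so this carbon carries the added methyl with the number held inside the scatter. Even the full replacement of 2-carboxyethyl by 1-((1H-tetrazol-5-yl)methyl)ethyl on a carbonyl carbon gives a 2.0-fold lower number from compound 1 to compound 3 (0.30 log units; within the scatter) and stays inside the scatter too. No measurement shown offers an explanation for these results. On these data alone, how an ethyl or a hydroxy group on this same carbon would read remains open.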